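A few compounds are considered here, and "the series" means these few. Any claim that something is new, unique, unknown or untested is made for them only; others in the source may bear on it.

Compound 2, `O=C(CSc1nncnc1-c1ccccc1Cl)Nc1ccccc1Cl`, was tested in an ADME assay on MT4 cells (Homo sapiens) for cytotoxicity, read by MTT assay (on this read-out lower numbers stand for higher toxicity in this test and higher numbers for lower toxicity in this test), and gave 90000 nM. Two other compounds of the same series were run in this assay as well: compound 1, `COC(=O)c1ccc(NC(=O)CSc2nncnc2-c2ccccc2Cl)c(Br)c1`, gave 59000 nM, and compound 3, `CCOC(=O)c1ccc(NC(=O)CSc2nncnc2-c2cccc3ccccc23)c(Cl)c1`, gave 150000 nM. The value of compound 2 is within the usual scatter of both the value of compound 1 and the value of compound 3, so no ranking among the three can be drawn from these numbers.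

Compound 4, `O=C(CSc1nncnc1-c1ccccc1Cl)Nc1ccccc1F`, differs from compound 2 in one place: fluoro in place of chloro on an aromatic carbon. For the measured compounds named here, no pair among the measured compounds shows the effect of this exchange, so nothing in the data anchors the size of the step. Given that the three measured values all lie close together, a step no larger than the scatter is expected, with no preferred direction. In this assay compound 4 is therefore estimated at 90000 nM, in a range from 40000 nM to 200000 nM. The expected step of no change at the digits printed from compound 2 to compound 4 (within the scatter) is thus essentially flat.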

Compound 4, half-maximal cytotoxic concentration: 98000 nM
Compound 4: middle estimate off by 1.1-fold (0.04 log units), on the low side, within the range that was stated.
By their numbers in this assay, from the lowest: compounds 1, 2, 4 and 3 (each within the scatter of the next, the first and the last beyond it).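

In this assay, fluoro in place of chloro on an aromatic carbon ortho to a large group gives a 1.1-fold higher number from compound 2 to compound 4 (0.04 log units; within the scatter), so the two halogens cannot be told apart at this position in this test. For the compounds shown here, the earlier compounds differed from one another in more than one place, and this pair is the first to isolate a single position, with a step that stays within the scatter. Nothing at hand offers an explanation for this result.

Going by these compounds, whether the position stays as silent with a group other than a halogen, such as an amine, a methoxy group or a carboxylic acid, remains open. Also open, on these data alone, is whether the same exchange would give a similar step on the other 2-chlorophenyl group, the one carried by the shared core.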